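This account rests on a few compounds, and the source may have more. Where it says the series, first, only, none or still open, it means among the compounds named here.

Working notes on the series in a functional assay on HeLa cells (Homo sapiens) for antiproliferative activity, read by MTT assay, with a stated time of 48 h; a higher number here means a weaker inhibitor, a lower number a stronger inhibitor. Compound 1 (`COc1ccc(C(=O)c2ccc(OC)c3c2OC(C)(C)C=C3)c(NC(=O)CO)c1`) gives 100 nM, compound 2 (`COc1ccc(C(=O)c2ccc(OC)c3c2OC(C)(C)C=C3)c(NC(=O)CN)c1`) gives 410 nM, and compound 3 (`CNCC(=O)Nc1cc(OC)ccc1C(=O)c1ccc(OC)c2c1OC(C)(C)C=C2`) gives 870 nM, the highest number of the three. Compound 4 (`COc1ccc(C(=O)c2ccc(OC)c3c2OC(C)(C)C=C3)c(NC(=O)CN(C)C)c1`) differs from compound 3 by methyl in place of hydrogen on an amine nitrogen. For the measured compounds named here, the closest precedent is the same replacement, a 2.1-fold higher number from compound 2 to compound 3 (0.33 log units; beyond the scatter), a modest step. The replacements of hydroxy, a 4.1-fold higher number from compound 1 to compound 2 (0.61 log units; beyond the scatter) and an 8.7-fold higher number from compound 1 to compound 3 (0.94 log units; beyond the scatter), run the same way but bear on it only indirectly. A further modest rise in the number is therefore expected, although a single precedent leaves its size open. The expected step is a 1.6-fold higher number from compound 3 to compound 4 (0.21 log units; within the scatter). For compound 4 the estimated value is 1400 nM, with an expected range of 550 nM to 3600 nM.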

Compound 4, half-maximal inhibitory concentration: 1050 nM
The estimate for compound 4 lay 1.3-fold (0.12 log units) above the measured number; measured number inside the range.
By their numbers in this assay, from the lowest: compound 1; then compound 2; then compounds 3 and 4 (each within the scatter of the next).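

In this assay, methyl in place of hydrogen on the amine nitrogen, made a second time, gives a 1.2-fold higher number from compound 3 to compound 4 (0.08 log units; within the scatter), whereas the first such replacement gave a 2.1-fold higher number from compound 2 to compound 3 (0.33 log units; beyond the scatter), so the step does not simply repeat. For the compounds shown here, the step from the amino group remains readable as a 2.6-fold higher number from compound 2 to compound 4 (0.41 log units; beyond the scatter), and dimethylamino in place of hydroxy gives an 11-fold higher number from compound 1 to compound 4 (1.02 log units; beyond the scatter), the only step printed as large. No measurement here bears on the cause of these steps.

Open, going by these compounds, is how methoxy or a carboxylic acid on the saturated chain carbon would compare with the hydroxy of compound 1. Also open, on these data alone, is what a piperidine ring or a longer chain would do in the amine series.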